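The source may hold more compounds than are shown below. What is called first, only, known or untested is meant among the compounds shown, and "the series" means these compounds.

In a functional assay on HeLa cells (Homo sapiens) for antiproliferative activity, read by cell counting, with a stated time of 72 h (on this read-out lower numbers stand for stronger inhibition and higher numbers for weaker inhibition), three compounds share one core and differ in a single group. Compound 1 `C#C[C@@]1(O)[C@@H](CO)O[C@@H](n2cnc3c(-c4ccc(C)cc4)ncnc32)[C@@H]1O` gives only a limit, > 250000 nM. Compound 2 `C#C[C@@]1(O)[C@@H](CO)O[C@@H](n2cnc3c(-c4ccc(OC)cc4)ncnc32)[C@@H]1O` also gives only a limit, > 250000 nM. Compound 3 `C#C[C@@]1(O)[C@@H](CO)O[C@@H](n2cnc3c(-c4ccc(Cl)cc4)ncnc32)[C@@H]1O` is the only one of the three with an actual number, 170000 nM. Compound 4 `C#C[C@@]1(O)[C@@H](CO)O[C@@H](n2cnc3c(-c4ccc(F)cc4)ncnc32)[C@@H]1O` carries fluoro in place of chloro on an aromatic carbon, para to a large group (fluoro in place of chloro on an aromatic carbon). The measured steps at this carbon are an at least 1.4-fold lower number from compound 1 to compound 3 (0.16 log units; that floor lies within the scatter) and an at least 1.4-fold lower number from compound 2 to compound 3 (0.16 log units; that floor lies within the scatter). Both are small floors, so neither points to a large effect. In this assay, the expected change is a 1.2-fold higher number from compound 3 to compound 4 (0.09 log units; within the scatter), with no shift beyond the scatter. For compound 4, the estimated value is 210000 nM, with an expected range of 120000 nM to 300000 nM.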

Compound 4, half-maximal inhibitory concentration: 220000 nM
Compound 4: the middle estimate sits 1.0-fold (0.02 log units) below what was measured; the measured number falls inside the stated range.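

In this assay, fluoro in place of chloro gives a 1.3-fold higher number from compound 3 to compound 4 (0.11 log units; within the scatter), so this position now has a second actual number, and the swap between these two groups leaves the activity unchanged within the scatter. The other two new steps are only floors, an at least 1.1-fold lower number from compound 2 to compound 4 (0.05 log units; that floor lies within the scatter) and an at least 1.1-fold lower number from compound 1 to compound 4 (0.05 log units; that floor lies within the scatter), because each starts from a limit: the limit of > 250000 nM in this assay, at which 2 of the 4 values shown sit.

As far as these compounds go, what an amine, a carboxylic acid or a longer chain would do on this carbon stays open. So does whether any group here can bring the number far under those of compound 3 and compound 4.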